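The compounds below may be only part of what the source reports. "The series", "measured", "known", "first", "only" and "open" are said of these compounds alone.

The study so far holds three compounds measured in an assay on a protein complex for inhibition of CDK8/Cyclin C (Homo sapiens), with a stated time of 1 h; a higher number here means a weaker inhibitor, a lower number a stronger inhibitor. Compound 2 `O=C(O)CCc1ccncc1-c1ccc2ccccc2c1` gives 50.5 nM, the lowest of the three numbers. Compound 1 `CNC(=O)/C=C/c1ccncc1-c1ccc2c(cnn2C)c1` gives 86.7 nM, a value within the scatter of compound 2, so the two cannot be ordered. Compound 3 `NC(=O)/C=C/c1ccncc1Br` gives 2420 nM, a number beyond the scatter above that of compound 2. Compound 4 `COC(=O)CCc1ccncc1-c1ccc2ccccc2c1` has not yet been measured in this assay. It differs from compound 2 by a single change: methyl in place of hydrogen on an oxygen next to a carbonyl group. Within the data shown here, no measured pair isolates this change, so its size is open. The expected step is a 2.0-fold higher number from compound 2 to compound 4 (0.30 log units; within the scatter), small and most likely within the scatter, if anything toward a weaker inhibitor. Compound 4 is therefore estimated at 100 nM, with a range from 35 nM to 300 nM.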

Compound 4, half-maximal inhibitory concentration: 259 nM
Beside the measured number, compound 4's estimate is 2.6-fold (0.41 log units) below it; the measured number falls inside the stated range.
By their numbers in this assay, from the lowest: compounds 2 and 1 (each within the scatter of the next); then compound 4; then compound 3.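

In this assay, among these compounds, methyl in place of hydrogen on an oxygen next to a carbonyl group gives a 5.1-fold higher number from compound 2 to compound 4 (0.71 log units; beyond the scatter), the only step here that isolates a single change, and it lies beyond the scatter. On this shared core, the carboxy group therefore gives a stronger inhibitor than methoxycarbonyl, though one pair sets no wider pattern. Nothing at hand accounts for the size of this step. As far as these compounds go, whether a primary amine, a tetrazole or a longer chain in that place would match the carboxy group remains open. So does the size of this change on another core.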